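This account rests on a few compounds, and the source may have more. Where it says the series, first, only, none or still open, it means among the compounds named here.

Measured compounds:
compound 1 `Nc1scc(CN2CCN(c3ccc(Cl)cc3F)CC2)c1C(=O)c1ccc(Cl)cc1` — -9.2%
compound 2 `Nc1scc(CN2CCN(c3ccncc3)CC2)c1C(=O)c1ccc(Cl)cc1` — -4%

In a functional assay on CHO cells with adenosine receptor A1 (Homo sapiens) as the target, read by cAMP accumulation and immunoassay, with a stated time of 6 min, tested at 0.01 uM (a higher number here means a weaker effect of the compound at the concentration tested, a lower number a stronger effect), compound 1 gives -9.2% and stands alongside compound 2, the two numbers lying within the scatter of each other. Compound 3 `Nc1scc(CN2CCN(c3cc(F)cc(F)c3)CC2)c1C(=O)c1ccc(Cl)cc1` differs from compound 1 by 3,5-difluorophenyl in place of 4-chloro-2-fluorophenyl on an amine nitrogen in a ring. For the measured compounds named here, the only measured step that bears on this change is the swap of the aryl group on the same ring nitrogen, a number 5.2 percentage points higher from compound 1 to compound 2 (within the scatter), which stayed within the scatter. A step of similar size, none beyond the scatter, is therefore expected: a number 2.2 percentage points higher from compound 1 to compound 3 (within the scatter). Compound 3 is estimated at -7%, in the range -20% to 8%.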

Compound 3, a percentage reported as activity, at one concentration (the size of the read-out at that concentration, not a potency): -13%
Beside the measured number, compound 3's estimate is 6 percentage points above it; measured number inside the range.
By their numbers in this assay, from the lowest: compounds 3, 1 and 2 (each within the scatter of the next).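

In this assay, 3,5-difluorophenyl in place of 4-chloro-2-fluorophenyl on the ring amine nitrogen gives a number 3.8 percentage points lower from compound 1 to compound 3 (within the scatter), and the same group in place of pyridin-4-yl gives a number 9 percentage points lower from compound 2 to compound 3 (within the scatter). Compound 3 thus adds a phenyl group carrying no chlorine, and all three groups at this position lie within the scatter of one another. From the compounds shown here alone, what remains open is whether an amine or a carboxylic acid on this aryl ring, or a longer chain on the nitrogen, would give a step beyond the scatter. No evidence at hand explains these numbers.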